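The source may hold more compounds than are shown below. What is called first, only, known or untested is meant among the compounds shown, and "the series" means these compounds.

Working notes on the series.

Compound 1 `CCCc1cc(-c2ccc(F)cc2)nn1Cc1ccc(C(=O)NO)cc1` and compound 2 `CCc1cc(-c2ccc(F)cc2)nn1Cc1ccc(C(=O)NO)cc1` share one core; compound 3 `CCCc1cc(-c2ccc(F)cc2)n(Cc2ccc(C(=O)NO)cc2)n1` and compound 4 `CCc1cc(-c2ccc(F)cc2)n(Cc2ccc(C(=O)NO)cc2)n1` share another, the same atoms joined differently. The difference between the two cores is not broken down here.

In a functional assay on HepG2 cells (Homo sapiens) for antiproliferative activity, read by MTT assay, with a stated time of 96 h (a lower number here means a stronger inhibitor of growth, a higher number a weaker inhibitor of growth), compound 1 gives 16800 nM. Compound 2 gives 16700 nM. The change between them is hydrogen in place of methyl on a saturated chain carbon, two bonds along the chain from an aromatic carbon, and its effect is a 1.0-fold lower number from compound 1 to compound 2 (0.00 log units; within the scatter). On this core the step is flat.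

Going by the values given here, compound 3 gives 6660 nM, the lowest of the three numbers so far, and its gap to compound 1 and to compound 2 lies beyond the scatter in both cases.

Compound 4 carries the same change relative to compound 3, namely (hydrogen in place of methyl on a saturated chain carbon, two bonds along the chain from an aromatic carbon). Among the compounds with values here, only one example of this change has been measured, on the other core, so the expectation rests on a single pairing. From compound 3 to compound 4 a step of about a 1.0-fold higher number from compound 3 to compound 4 (0.00 log units; within the scatter) is expected, because a 1.0-fold lower number from compound 1 to compound 2 (0.00 log units; within the scatter) showed the same change to be flat on the core of compound 1.

For compound 4 the expected value is therefore 6700 nM, with a range from 3300 nM to 13500 nM allowing for the usual scatter and for the core being different.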

Compound 4, concentration for 50% growth inhibition: 7760 nM
Estimate against measurement, compound 4: 1.2-fold (0.06 log units) below; low and high end bracket the measured number.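

On the second core, in this assay, the shortening of propyl to ethyl gives a 1.2-fold higher number from compound 3 to compound 4 (0.07 log units; within the scatter), so the change is flat there as well. Set beside the earlier step, the two results do not differ: the same change on two cores in this assay, a 1.0-fold lower number (0.00 log units; within the scatter) from compound 1 to compound 2 and a 1.2-fold higher number (0.07 log units; within the scatter) from compound 3 to compound 4, 1.2-fold (0.07 log units) apart, within the scatter of two such steps. This shows that, for this one small change, the flat step carries from the core of compound 1 to the core of compound 3; it rests on a single pair per core and a single assay, however, and a step with no measurable size is a weak test of transfer, since it cannot show whether a larger effect would carry across in the same way.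

The compounds shown leave open whether a longer chain such as butyl, or a chain end bearing an amine or a carboxylic acid in place of the propyl or ethyl group, would stay equally flat on either core, or would instead move the number and separate the two cores. They also leave open whether the flat step seen in this assay would hold in any other assay or on any further core in the series.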